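Cyclopropyl for tert-butyl on a sulfonamide nitrogen

The source may report more compounds than this note shows. Statements on the series, on what has been measured and on what is new or still open speak of the compounds shown alone.

- compound 1 `CC(C)CN(Cc1ccc(N2CCN(C)CC2)cc1)S(=O)(=O)Cc1ccccc1`: 60000 nM
- compound 2 `CC(=O)N1CCN(c2ccc(CN(C(C)(C)C)S(=O)(=O)Cc3ccccc3)cc2)CC1`: <= 1000 nM

Going by the values given here, only two compounds have been tested so far in a physicochemical assay for solubility, in phosphate buffer, measured as kinetic solubility, with a stated time of 24 h, at pH 7.4; a lower number here means a less soluble compound, a higher number a more soluble compound. Compound 1 gives a true number, 60000 nM. Compound 2 gives only a limit, <= 1000 nM, and not a number. These two compounds differ in more than one place, so their values cannot be pinned on any single change.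

The next compound, compound 3 `CC(=O)N1CCN(c2ccc(CN(C3CC3)S(=O)(=O)Cc3ccccc3)cc2)CC1`, matches compound 2 except for one group: cyclopropyl in place of tert-butyl on a sulfonamide nitrogen. Among the compounds with values here, no measured pair shows this swap, so the expectation in this assay is only a rough one. A small upward step is expected, and it starts from the limit of compound 2, <= 1000 nM. Compound 3 may also return only a limit. The expected change is an at least 2.0-fold higher number from compound 2 to compound 3 (0.30 log units; that floor lies within the scatter). For compound 3 the estimate is 2000 nM, with an expected range from 1000 nM to 8000 nM.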

Compound 3, solubility: 71000 nM
Compound 3: the middle estimate sits 36-fold (1.55 log units) below what was measured; the measured number lies above the stated range.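

On a sulfonamide nitrogen whose other neighbours are a saturated chain carbon and a sulfonyl sulfur, replacing tert-butyl with cyclopropyl moves the read-out in this assay well beyond the usual scatter: an at least 71-fold higher number from compound 2 to compound 3 (1.85 log units; beyond the scatter). This is the first pair shown that differs in one place only, so this step, unlike the gap between compound 1 and compound 2, can be tied to a single change of group. Its full size stays unknown, since compound 2 gives only a limit and the step is therefore a floor rather than an exact figure: the limit of <= 1000 nM in this assay, at which 1 of the 3 values shown sits.

On these data alone, this single pair cannot separate the effect of the new ring from that of the one fewer carbon, so it remains open whether an isopropyl group or a cyclobutyl ring on this nitrogen would read like cyclopropyl or like tert-butyl. As far as these compounds go, it is also open whether the same swap would give a step of this kind on another core, such as the core of compound 1, which carries a methyl group rather than an acetyl group on its piperazine.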